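The source may report more compounds than this note shows. Statements on the series, on what has been measured and on what is new or still open speak of the compounds shown alone.

For the measured compounds named here, compound 2 `C=CC(=O)Nc1cccc(NC(=O)CSc2nc(Nc3ccc(CC)cc3)c3ccccc3n2)c1` carries the lower of the two numbers so far in a functional assay on NCI-H1975 cells (Homo sapiens) for inhibition, read by MTT assay, with a stated time of 72 h (a higher number here means a weaker inhibitor, a lower number a stronger inhibitor), giving 8270 nM; compound 1 `C=CC(=O)Nc1cccc(NC(=O)CSc2nc(Nc3ccccc3Br)c3ccccc3n2)c1` gives 19300 nM, and the step of a 2.3-fold lower number from compound 1 to compound 2 (0.37 log units; beyond the scatter) separates them. Compound 3 `C=CC(=O)Nc1cccc(NC(=O)CSc2nc(Nc3ccc(Cl)cc3Cl)c3ccccc3n2)c1` differs from compound 2 by 2,4-dichlorophenyl in place of 4-ethylphenyl on a nitrogen on an aromatic ring. Going by the values given here, only that one step bears on the change, and it ran from an aryl bearing a single halogen to the ethyl-bearing aryl; the reverse direction is the nearer guide. A modest rise in the number is therefore expected for compound 3, a 1.5-fold higher number from compound 2 to compound 3 (0.16 log units; within the scatter), toward compound 1 rather than past it. Compound 3 is estimated at 12000 nM, within 4000 nM to 40000 nM.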

Compound 3, half-maximal inhibitory concentration: 5990 nM
Estimate against measurement, compound 3: 2.0-fold (0.30 log units) above; the measured number falls inside the stated range.
By their numbers in this assay, from the lowest: compounds 3 and 2 (each within the scatter of the next); then compound 1.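

Across the aryl groups on this nitrogen, a 1.4-fold lower number from compound 2 to compound 3 (0.14 log units; within the scatter) in this assay leaves 2,4-dichlorophenyl and 4-ethylphenyl unresolved, so the ethyl group is not needed to reach this level. Halogen on the aryl does not by itself place a compound with compound 1, as a 3.2-fold lower number from compound 1 to compound 3 (0.51 log units; beyond the scatter) shows for 2,4-dichlorophenyl in place of 2-bromophenyl. No measurement at hand accounts for either step.

Open, from the compounds shown here alone, is how this position responds to an aryl carrying an amine, a carboxylic acid or a methoxy group. Also open, going by these compounds, is whether the two chlorines contribute singly, as 4-chlorophenyl or 2-chlorophenyl would show.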